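Thiophene for Phenyl on the Pyridine Arm

The source may hold more compounds than are shown below. What is called first, only, known or untested is meant among the compounds shown, and "the series" means these compounds.

In a functional assay on MCF7 cells (Homo sapiens) for inhibition, with a stated time of 72 h (a lower number here means a stronger inhibitor, a higher number a weaker inhibitor), compound 2 `NC1CCC(Nc2nc(NCc3ccc(-c4ccccc4)nc3)c3ncn(C4CCCC4)c3n2)CC1` gives 483 nM, the higher of the two numbers recorded, while compound 1 `NC1CCC(Nc2nc(NCc3ccc(-c4ccsc4)cc3)c3ncn(C4CCCC4)c3n2)CC1` gives 145 nM. Going by the values given here, the only step known, a 3.3-fold higher number from compound 1 to compound 2 (0.52 log units; beyond the scatter), alters both rings of the arm at once and so bears only partly on the change to compound 3 `NC1CCC(Nc2nc(NCc3ccc(-c4cccs4)nc3)c3ncn(C4CCCC4)c3n2)CC1`: thiophen-2-yl in place of phenyl on an aromatic carbon. Because the thiophene-bearing compound 1 gave 145 nM, a modest fall in this assay is expected for compound 3. Compound 3 is therefore estimated at 300 nM, within 120 nM to 750 nM, an expected step of a 1.6-fold lower number from compound 2 to compound 3 (0.21 log units; within the scatter).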

Compound 3, half-maximal inhibitory concentration: 92 nM
The estimate for compound 3 lay 3.3-fold (0.51 log units) above the measured number; measured number outside the range, below it.
By their numbers in this assay, from the lowest: compounds 3 and 1 (each within the scatter of the next); then compound 2.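

In this assay the exchange of phenyl for thiophen-2-yl, on the aromatic carbon next to the ring nitrogen, gives a 5.3-fold lower number from compound 2 to compound 3 (0.72 log units; beyond the scatter) and isolates this one ring, which the earlier step could not do. The arm of compound 3 keeps its pyridine and still shows a 1.6-fold lower number from compound 1 to compound 3 (0.20 log units; within the scatter) against the arm of compound 1, a difference within the scatter. Nothing on hand accounts for either step.

As far as these compounds go, whether thiophen-3-yl or furan-2-yl would serve at this position remains open, as does the effect of a methyl or an amine on the thiophene.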